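Aryl sulfonyl swap across two amide pairings

The source may report more compounds than this note shows. Statements on the series, on what has been measured and on what is new or still open speak of the compounds shown alone.

Compound 1 `O=C(CCC(NS(=O)(=O)c1ccc(Br)cc1)C(=O)NC1CCCCC1)NC1CCCCC1` bears a 4-bromophenyl on the sulfonyl sulfur and two cyclohexyl amides. In a functional assay on IMR-32 cells (Homo sapiens) for cytotoxicity, read by MTT assay, tested at 60 ug/mL (on this read-out higher numbers stand for more inhibition at the one concentration tested (going by the name of the read-out) and lower numbers for less inhibition), compound 1 gives 18.4%. Compound 3 `O=C(CCC(NS(=O)(=O)c1ccc(Cl)c(Cl)c1)C(=O)NC1CCCCC1)NC1CCCCC1` differs from it in one place: 3,4-dichlorophenyl in place of 4-bromophenyl on a sulfonyl sulfur. In this assay compound 3 gives 24%, which is a number 5.6 percentage points higher from compound 1 to compound 3 (within the scatter).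

Compound 2 `O=C(CCC(NS(=O)(=O)c1ccc(Br)cc1)C(=O)NCc1ccccc1)NCc1ccccc1` keeps the 4-bromophenyl but carries benzyl amides; the difference between the cores of compound 1 and compound 2 is not broken down here. In this assay compound 2 gives "not determined" (no result reported), so no number is available for it.

Compound 4 `O=C(CCC(NS(=O)(=O)c1ccc(Cl)c(Cl)c1)C(=O)NCc1ccccc1)NCc1ccccc1` stands to compound 2 as compound 3 stands to compound 1: 3,4-dichlorophenyl in place of 4-bromophenyl on a sulfonyl sulfur. The place is the same in both pairs, a sulfonyl sulfur whose other neighbour is the sulfonamide nitrogen, so the change is the same. With no number for compound 2, the expectation for compound 4 rests on compound 1 and compound 3 only, and is expected small because a number 5.6 percentage points higher from compound 1 to compound 3 (within the scatter). Compound 4 is therefore estimated at 22%, expected between 8% and 38%.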

Compound 4, a percentage reported as inhibition, at one concentration (the size of the read-out at that concentration, not a potency): 11.4%
Estimate against measurement, compound 4: 10.6 percentage points above; the range from low to high includes it.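

In this assay, going by these compounds alone, compound 2 has no number, so no step from compound 2 to compound 4 can be read. The compounds shown leave open whether 3,4-dichlorophenyl in place of 4-bromophenyl on a sulfonyl sulfur has the same outcome with benzyl amides as with cyclohexyl amides. No evidence at hand bears on the result of compound 4.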